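Notes on the aryl group in the shared core

The source may report more compounds than this note shows. Statements on the series, on what has been measured and on what is new or still open speak of the compounds shown alone.

Measured in a functional assay on the whole organism with Rattus norvegicus as the target, at a dose of 3 mg/kg by the oral route; a lower number here means a weaker effect, a higher number a stronger effect of the compound at the dose given:
compound 1 `Cc1cc(C(=O)Nc2nn[nH]n2)nc(-c2ccccc2)c1` gives 50%
compound 2 `COc1ccc(-c2cc(C)cc(C(=O)Nc3nn[nH]n3)n2)cc1` gives 43%
compound 3 `Cc1cccc(-c2cc(C)cc(C(=O)Nc3nn[nH]n3)n2)c1` gives 61%

Compound 3 stands highest of the three numbers. Compound 1 is nearest and compound 2 furthest, and both gaps to compound 3 lie beyond the scatter. The step of a number 11 percentage points higher from compound 1 to compound 3 (beyond the scatter) is modest but beyond the scatter, whereas a number 7 percentage points lower from compound 1 to compound 2 (within the scatter) stays within it.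

Compound 4 `Cc1ccc(-c2cc(C)cc(C(=O)Nc3nn[nH]n3)n2)cc1` has not yet been measured. The change from compound 3 is 4-methylphenyl in place of 3-methylphenyl on an aromatic carbon. Among the compounds with values here, no measured pair shows this exact rearrangement, so two steps bear on it indirectly. a number 11 percentage points higher from compound 1 to compound 3 (beyond the scatter) shows what a methyl on the aryl ring gave when placed as in compound 3. a number 7 percentage points lower from compound 1 to compound 2 (within the scatter) shows that a group placed as in compound 2 gave no movement beyond the scatter. Whether the gain of compound 3 survives the move of the methyl is open; the nearest comparison, compound 2, does not encourage it.

Compound 4 is therefore expected to sit nearer compound 1 than compound 3, at an estimated 50% with a range of 35% to 65%. This amounts to an expected step of a number 11 percentage points lower from compound 3 to compound 4 (beyond the scatter), downward, and of a size that may or may not clear the scatter.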

Compound 4, a percentage reported as inhibition, in the whole organism at one dose (the size of the read-out at that dose, not a potency): 100%
Compound 4: middle estimate off by 50 percentage points, on the low side, and the stated range ends below it.
By their numbers in this assay, from the lowest: compounds 2 and 1 (each within the scatter of the next); then compound 3; then compound 4.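

With the same atoms joined differently, the change from 3-methylphenyl to 4-methylphenyl in this assay gives a number 39 percentage points higher from compound 3 to compound 4 (beyond the scatter), so at this place on the aromatic ring next to the ring nitrogen, where the methyl sits on the aryl group matters, and not only whether one is present. Against the unsubstituted phenyl of compound 1, the 4-methylphenyl group gives a number 50 percentage points higher from compound 1 to compound 4 (beyond the scatter), and methyl in place of methoxy gives a number 57 percentage points higher from compound 2 to compound 4 (beyond the scatter), so the identity of the group on the aryl ring also matters, with methoxy and methyl far apart in their outcome. No measurement at hand accounts for either gap.

Still open, on these data alone, is whether the gain is specific to methyl or extends to an ethyl, a chlorine, a trifluoromethyl or an amine placed as in the 4-methylphenyl group. Also open, as far as these compounds go, is how compound 3 and compound 4 compare at other doses, since each read-out here comes from one oral dose and describes the size of the effect at that dose, not a potency.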